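Working notes on the series: from compound 2 to compound 4

The source may hold more compounds than are shown below. What is called first, only, known or untested is meant among the compounds shown, and "the series" means these compounds.

Of the compounds shown here, three have been tested in a functional assay on HeLa cells (Homo sapiens) for cytotoxicity, read by WST assay, with a stated time of 48 h; on this read-out higher numbers stand for weaker inhibition and lower numbers for stronger inhibition. Compound 1 `COc1cccc([C@H](O)[C@H]2CO[C@H](c3ccc(OC)c(OC)c3)[C@@H](C/C=C/c3ccc(OC)c(OC)c3)C2)c1` gives 21200 nM. Compound 2 `Cc1ccc(/C=C/C[C@H]2C[C@@H]([C@@H](O)c3ccccc3)CO[C@@H]2c2ccccc2)cc1C` gives 10000 nM, the lowest number of the three; the nearest to it is compound 1, whose number stands higher by a margin beyond the scatter, and the furthest is compound 3. Compound 3 `COc1ccc(CCC[C@@H]2C[C@@H]([C@@H](O)c3ccc(OC)c(OC)c3)CO[C@H]2c2ccc(OC)c(OC)c2)cc1OC` gives 35700 nM, the highest number of the three.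

Compound 4 `O[C@@H](c1ccccc1)[C@H]1CO[C@H](c2ccccc2)[C@@H](C/C=C/c2ccncc2)C1` has not yet been measured in this assay. It differs from compound 2 in one place: pyridin-4-yl in place of 3,4-dimethylphenyl on a double-bonded chain carbon bound to a double-bonded chain carbon. Among the measured compounds shown here, no pair among the measured compounds differs in that one place, so nothing tested so far shows what pyridin-4-yl in place of 3,4-dimethylphenyl on a double-bonded chain carbon does to the read-out. With no guide in the data, the step is expected to be small, likely within or only just beyond the scatter, and a slight weakening is taken as the middle case: a 1.5-fold higher number from compound 2 to compound 4 (0.18 log units; within the scatter). Compound 4 is accordingly estimated at 15000 nM, with a range from 5000 nM to 50000 nM.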

Compound 4, half-maximal inhibitory concentration: > 100000 nM
Compound 4 was reported as a limit (the forecaster's own chance of this, stated with the estimate: 15%); middle value at least 6.6-fold (0.82 log units) from the limit.
By their numbers in this assay, from the lowest: compound 2; then compounds 1 and 3 (each within the scatter of the next). At a limit, above all of these: compound 4.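

In this assay, among the compounds shown here, pyridin-4-yl in place of 3,4-dimethylphenyl on a double-bonded chain carbon bound to a double-bonded chain carbon gives an at least 10-fold higher number from compound 2 to compound 4 (1.00 log units; beyond the scatter), the first reading of a change at this place. This position is therefore not indifferent to the read-out, at least for this pair, which no earlier comparison could show. Compound 4 gives > 100000 nM, which is a limit of the assay, so the full size of the step cannot be read: the limit of > 100000 nM in this assay, at which 1 of the 4 values shown sits.

The compounds shown leave open whether the step goes with the ring nitrogen or with the loss of the two methyl groups. As far as these compounds go, a pyridin-3-yl or a 4-aminophenyl group at this place would bear on that question, and how far the tolerated groups extend remains open.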